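Replacing 1-acetylazetidin-3-yl in compound 3

The compounds below may be only part of what the source reports. "The series", "measured", "known", "first", "only" and "open" are said of these compounds alone.

Of the compounds shown here, three have been read so far. In a physicochemical assay for solubility, measured as kinetic solubility (on this read-out higher numbers stand for higher solubility and lower numbers for lower solubility), compound 1 `Cc1ccc(S(=O)(=O)Nc2ccc(CN(C)[C@@H]3CCN(C(=O)c4cccc(Cl)c4)C3)cc2)cc1` gives 28000 nM, and compound 2 `COc1ccc(S(=O)(=O)Nc2ccc(CN3C[C@@H]4C[C@H]3CN4C(=O)c3cccc(Cl)c3)cc2)cc1` gives 47000 nM. Compound 3 `COc1ccc(S(=O)(=O)Nc2ccc(CN3CCN(C(=O)C4CN(C(C)=O)C4)CC3)cc2)cc1` reads >= 511000 nM, which is a limit of the assay and not a number.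

The next compound, compound 4 `COc1ccc(S(=O)(=O)Nc2ccc(CN3CCN(C(=O)C4CCCN(C)C4)CC3)cc2)cc1`, carries 1-methylpiperidin-3-yl in place of 1-acetylazetidin-3-yl on a carbonyl carbon. Going by the values given here, no pair of measured compounds differs in one place only, so the series offers no direct precedent for the size of this change. A moderate downward move in this assay is expected, with some chance of no visible change. The expected step is an at least 1.7-fold lower number from compound 3 to compound 4 (0.23 log units; that floor lies within the scatter), and it is only a rough estimate. This expectation starts from compound 3 at >= 511000 nM, a limit, so the true size of the step may be larger. For compound 4 the estimated value is 300000 nM, with an expected range of 100000 nM to 520000 nM.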

Compound 4, solubility: >= 526000 nM
Compound 4: only a limit was reported (the forecaster's own chance of this, stated with the estimate: 35%); middle value at least 1.7-fold (0.24 log units) away from the limit.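

In this assay, going by these compounds alone, compound 4 reads >= 526000 nM, which is a limit of the assay; compound 3 also stands only as a limit, and no step from compound 3 to compound 4 can be read. The compounds shown leave open how far 1-methylpiperidin-3-yl and 1-acetylazetidin-3-yl differ in this assay.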